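This account rests on a few compounds, and the source may have more. Where it says the series, first, only, none or still open, it means among the compounds named here.

Compound 1 `O=C1COc2ccc(-c3cnc(Cl)c(NS(=O)(=O)c4ccc(F)cc4)c3)cc2N1c1ccc(F)cc1` — 32600 nM
Compound 2 `COc1ncc(-c2ccc3c(c2)N(c2ccc(F)cc2)C(=O)CO3)cc1NS(=O)(=O)c1ccc(F)cc1` — > 40000 nM
Compound 3 `O=C1COc2ccc(-c3cccc(NS(=O)(=O)c4ccc(F)cc4)c3)cc2N1c1ccc(F)cc1` — > 40000 nM

Three compounds on a shared core were tested in a functional assay on MCF7 cells (Homo sapiens) for antiproliferative activity, read by MTT assay, with a stated time of 72 h; a higher number here means a weaker inhibitor, a lower number a stronger inhibitor. Compound 1 gives 32600 nM. For compound 2 the reading is a limit of the assay, > 40000 nM, not a number. For compound 3 the reading is likewise a limit, > 40000 nM. Compound 2 therefore stands at the limit of > 40000 nM in this assay, at which 2 of the 3 values shown sit, with no measured value inside the working range of this assay.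

Going by the values given here, only one measured step joins two neighbours: an at least 1.2-fold higher number from compound 1 to compound 2 (0.08 log units; that floor lies within the scatter). It is a floor that lies within the scatter, and it concerns the methoxy in place of chloro, not the 4-fluorophenyl.

Compound 4 `COc1ncc(-c2ccc3c(c2)N(c2ccccc2)C(=O)CO3)cc1NS(=O)(=O)c1ccc(F)cc1` has not been measured. It differs from compound 2 by hydrogen in place of fluoro on an aromatic carbon. Among the compounds with values here, no measured step touches this part of the molecule, so the measured data give no guide to the direction or size of the change. The small size of the difference, a single fluorine leaving, gives no reason to expect a step beyond the scatter. With compound 2 sitting at a limit, compound 4 is expected to give about 50000 nM, within 25000 nM to 120000 nM, and most likely to be reported again only as a limit. The expected step that the limit leaves unreadable from compound 2 to compound 4 is estimated to be none beyond the scatter.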

Compound 4, half-maximal inhibitory concentration: 8870 nM
Compound 4: middle estimate off by 5.6-fold (0.75 log units), on the high side; measured number outside the range, below it.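

The change from 4-fluorophenyl to phenyl gives, in this assay, an at least 4.5-fold lower number from compound 2 to compound 4 (0.65 log units; beyond the scatter). Until this result, the only step between neighbours concerned methoxy in place of chloro, and its floor lay within the scatter; the aromatic carbon para to a large group on the phenyl ring is the first place in this series where a single change is shown to move the reading beyond the scatter, and it brings a compound carrying the methoxy group from a limit to a number within the working range. The true size of the step remains unknown because compound 2 has only a limit and no number: the limit of > 40000 nM in this assay, at which 2 of the 4 values shown sit.

The compounds shown leave open whether hydrogen in place of fluoro would give a similar step alongside the chloro group of compound 1 or on the ring of compound 3, which carries neither chloro nor methoxy. They also leave open how a methyl group, an amine or a carboxylic acid at this same place would read, and so whether any group there can match or improve on the hydrogen of compound 4.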